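The compounds below may be only part of what the source reports. "The series", "measured", "known", "first", "only" and "open" are said of these compounds alone.

Notes on the sulfonamide ether series. Compound 1 `CNC(=O)c1cc(Oc2cccc(NS(=O)(=O)c3cccc(C(F)(F)F)c3)c2)ccn1` carries a trifluoromethyl on the arylsulfonyl ring; in a functional assay on PLC5 cells (Homo sapiens) for inhibition, read by MTT assay, with a stated time of 24 h (on this read-out lower numbers stand for stronger inhibition and higher numbers for weaker inhibition), compound 1 gives 8400 nM. For the measured compounds named here, that is the only number in the set so far. Compound 2 `CNC(=O)c1cc(Oc2cccc(NS(=O)(=O)c3ccccc3)c2)ccn1` differs from it by hydrogen in place of trifluoromethyl on an aromatic carbon; in this assay compound 2 reaches only a limit, > 15000 nM. The step of an at least 1.7-fold higher number from compound 1 to compound 2 (0.25 log units; that floor lies within the scatter) therefore cannot be sized properly, since the limit of > 15000 nM in this assay, at which 1 of the 2 values shown sits, marks where the read-out stops. Compound 3 `Nc1ccc(Oc2cccc(NS(=O)(=O)c3cccc(C(F)(F)F)c3)c2)cc1N` keeps the trifluoromethyl sulfonamide and changes the other end of the molecule: 3,4-diaminophenyl in place of 2-(methylcarbamoyl)pyridin-4-yl on an oxygen on an aromatic ring. Going by the values given here, no measured step touches that oxygen-linked ring, so the only guide is that compound 1 already sits close to the edge of the measurable range, and that the one change tried so far, an at least 1.7-fold higher number from compound 1 to compound 2 (0.25 log units; that floor lies within the scatter), ran straight into the limit. For compound 3 the step of a 1.7-fold higher number from compound 1 to compound 3 (0.22 log units; within the scatter) is expected to go toward weaker inhibition, with a real chance that this assay returns only a limit. The estimate for compound 3 is 14000 nM, range 5000 nM to 40000 nM.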

Compound 3, half-maximal inhibitory concentration: > 15000 nM
Compound 3: a limit, no number (the forecaster's own chance of this, stated with the estimate: 45%); middle value at least 1.0-fold (0.02 log units) away from the limit.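

The change at the oxygen-linked end of the molecule can be read only as a floor: an at least 1.7-fold higher number from compound 1 to compound 3 (0.25 log units; that floor lies within the scatter). In this assay compound 3 gives > 15000 nM, which is a limit and not a number. With the trifluoromethyl sulfonamide kept, 3,4-diaminophenyl in place of 2-(methylcarbamoyl)pyridin-4-yl therefore gives no sized step, and a change at either end of compound 1 has now ended at the same edge of the read-out: the limit of > 15000 nM in this assay, at which 2 of the 3 values shown sit.

From the compounds shown here alone, it remains open whether compound 3 truly differs from compound 1, since the floor of the step lies within the scatter, and how far compound 2 and compound 3 lie past the limit. Also open, going by these compounds, is whether any other group on that oxygen would give a measurable number in this assay, for instance a phenyl ring carrying a single amine, or a pyridine ring carrying a carboxylic acid in place of the methylcarbamoyl group.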